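Removing a Fluoro Substituent in a Glucagon Receptor Antagonist Series

This account rests on a few compounds, and the source may have more. Where it says the series, first, only, none or still open, it means among the compounds named here.

This account follows a small series measured in a functional assay on cells for antagonist activity at Glucagon receptor (Homo sapiens), read by cAMP accumulation, in the presence of a further agent that is not named here; on this read-out higher numbers stand for weaker inhibition and lower numbers for stronger inhibition. Three compounds have numbers. Compound 1 `CCCC(Oc1ccc(-n2cc(C(F)(F)F)cn2)c(C)c1)c1ccc(C(=O)NCCC(=O)O)cc1` gives 1900 nM, compound 2 `CCCC(Oc1ccc(-n2cc(F)cn2)cc1)c1ccc(C(=O)NCCC(=O)O)cc1` gives 10000 nM, and compound 3 `O=C(O)CCNC(=O)c1ccc(C(Oc2ccc(-n3cc(C(F)(F)F)cn3)cc2)C2CC2)cc1` gives 15000 nM. Compound 2 stands second highest of the three; its nearest neighbour is compound 3, which lies within the usual scatter of it, while compound 1 is clearly the furthest and sits well beyond the scatter on the stronger side. No two measured compounds differ in only one place, so no single step can be read directly from the numbers shown.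

The step now considered goes from compound 2 to compound 4 `CCCC(Oc1ccc(-n2cccn2)cc1)c1ccc(C(=O)NCCC(=O)O)cc1`, which has not yet been measured in this assay. The change is hydrogen in place of fluoro on an aromatic carbon, or put another way, 4-fluoro-1H-pyrazol-1-yl becomes 1H-pyrazol-1-yl. It is the loss of a single heavy atom on the outer ring.

Compound 4 is expected to sit close to compound 2, with a step of a 1.5-fold higher number from compound 2 to compound 4 (0.18 log units; within the scatter) that is small and, if anything, toward a weaker number, because compound 2 already gives 10000 nM and the change is slight. Compound 4 is therefore estimated at 15000 nM, with a range from 5000 nM to 40000 nM.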

Compound 4, antagonist equilibrium constant: > 55000 nM
Compound 4: a limit, no number (the forecaster's own chance of this, stated with the estimate: 20%); middle value at least 3.6-fold (0.56 log units) from the limit.
By their numbers in this assay, from the lowest: compound 1; then compounds 2 and 3 (each within the scatter of the next). At a limit, above all of these: compound 4.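

Hydrogen in place of fluoro on an aromatic carbon of the five-membered aromatic ring gives an at least 5.5-fold higher number from compound 2 to compound 4 (0.74 log units; beyond the scatter) and this is the first change in the series that can be read at a single place. In this assay compound 4 gives > 55000 nM which is a limit of the assay and not a number. Going by these compounds, the single fluorine atom on the 4-fluoro-1H-pyrazol-1-yl group of compound 2 therefore matters at this position, although the full size of the step stays unknown and only its lower bound can be stated: the limit of > 55000 nM in this assay, at which 1 of the 4 values shown sits.

The compounds shown leave open how a chlorine atom, a methyl group or a nitrile on this same carbon would compare with fluoro on the otherwise unchanged core of compound 2. On these data alone, compound 1 and compound 3 both carry trifluoromethyl at this place, but each differs from compound 2 in more than one place, so those steps cannot be read and the effect of trifluoromethyl alone on that core also remains open.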